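The source may hold more compounds than are shown below. What is called first, only, known or untested is meant among the compounds shown, and "the series" means these compounds.

Measured compounds:
compound 1, `COc1ccc(C(=O)Nc2cccc(-c3oc4cc(-c5ccc(F)cc5)ccc4c(=O)c3O)c2)cc1`, 21100 nM in a functional assay on GTL 16 cells for antiproliferative activity against GTL 16 cell line (Homo sapiens), read by CCK-8 assay, with a stated time of 72 h; a lower number here means a stronger inhibitor, a higher number a weaker inhibitor
compound 2, `O=C(Nc1cccc(-c2oc3cc(-c4ccc(F)cc4)ccc3c(=O)c2O)c1)c1ccc(Cl)cc1`, 9140 nM in this assay
compound 3, `COc1ccccc1C(=O)Nc1cccc(-c2oc3cc(-c4ccc(F)cc4)ccc3c(=O)c2O)c1`, 6370 nM in this assay

Among these three, compound 1 gives the highest number in this assay, which here means the weakest inhibitor; compound 2 sits closest to it and compound 3 furthest from it. Compound 4, `COc1cccc(C(=O)Nc2cccc(-c3oc4cc(-c5ccc(F)cc5)ccc4c(=O)c3O)c2)c1`, is not yet measured. It differs from compound 1 in one respect: 3-methoxyphenyl in place of 4-methoxyphenyl on a carbonyl carbon. Among the measured compounds shown here, one measured step bears on this change most directly, since it too swaps one methoxyphenyl for another: a 3.3-fold lower number from compound 1 to compound 3 (0.52 log units; beyond the scatter). The replacement of the group itself, a 2.3-fold lower number from compound 1 to compound 2 (0.36 log units; beyond the scatter), points the same way. Both steps are modest, so for compound 4 a modest step in the same direction is expected, a lower number than compound 1 rather than a large shift. The estimate for compound 4 is 10000 nM, with a range from 4000 nM to 25000 nM. This corresponds to an expected step of a 2.1-fold lower number from compound 1 to compound 4 (0.32 log units; beyond the scatter).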

Compound 4, half-maximal inhibitory concentration: 12500 nM
Compound 4: middle estimate off by 1.3-fold (0.10 log units), on the low side; low and high end bracket the measured number.
By their numbers in this assay, from the lowest: compounds 3, 2, 4 and 1 (each within the scatter of the next, the first and the last beyond it).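

In this assay, compound 4 cannot be separated from any of the other three compounds (steps: a 1.7-fold lower number from compound 1 to compound 4 (0.23 log units; within the scatter); a 2.0-fold higher number from compound 3 to compound 4 (0.29 log units; within the scatter); a 1.4-fold higher number from compound 2 to compound 4 (0.14 log units; within the scatter)). The 2-methoxyphenyl and 4-methoxyphenyl compounds do stand apart (a 3.3-fold lower number from compound 1 to compound 3 (0.52 log units; beyond the scatter)), but the 3-methoxyphenyl group sides with neither, so these numbers support no graded order as the methoxy group changes place on this ring. Nothing available explains the result.

Every group shown on this carbonyl carbon is a phenyl ring carrying one methoxy or chloro group, so it remains open whether the 2-chlorophenyl or 3-chlorophenyl group would follow the methoxy results. On these data alone, it also remains open whether a phenyl ring carrying a carboxylic acid or a dimethylamino group, or a pyridine ring, would shift the number beyond the scatter.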